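Chloro in Place of Methyl on the Core of Compound 1

The compounds below may be only part of what the source reports. "The series", "measured", "known", "first", "only" and "open" are said of these compounds alone.

Measured compounds:
compound 1, `CC#C[C@@H](Cc1nnn[nH]1)c1ccc(OCc2cc(C)c3scc(-c4ccccc4C)c3c2)cc1`, 213 nM
compound 2, `CC#C[C@@H](Cc1nnn[nH]1)c1ccc(OCc2ccc3scc(-c4cccnc4C)c3c2)cc1`, 20 nM

Both were tested in a functional assay on cells for agonist activity at Free fatty acid receptor 1 (Rattus norvegicus), read by FLIPR and calcium flux; a higher number here means that more compound is needed for the effect, a lower number that less compound is needed. Compound 1 gives 213 nM, the highest of the two numbers. Compound 2 gives 20 nM, a lower number beyond the scatter; compound 2 differs from compound 1 in more than one place, so these two values say nothing about any single change.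

Compound 3, `CC#C[C@@H](Cc1nnn[nH]1)c1ccc(OCc2cc(Cl)c3scc(-c4ccccc4C)c3c2)cc1`, has not yet been measured. It differs from compound 1 by chloro in place of methyl on an aromatic carbon. Within the data shown here, no measured pair shows this exchange, so its size is unknown. In this assay the step is expected to be small, within the scatter, with no clear direction. For compound 3 the expected value is 160 nM, with a range from 50 nM to 500 nM. The estimated step is a 1.3-fold lower number from compound 1 to compound 3 (0.12 log units; within the scatter).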

Compound 3, half-maximal effective concentration: 108 nM
For compound 3 the middle estimate is 1.5-fold (0.17 log units) above the measured one, and the stated range covers the measured number.
By their numbers in this assay, from the lowest: compound 2; then compounds 3 and 1 (each within the scatter of the next).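

In this assay, among these compounds, chloro in place of methyl on this aromatic carbon gives a 2.0-fold lower number from compound 1 to compound 3 (0.29 log units; within the scatter) and so provides the first reading of a change at one place alone. At this position, ortho to a fused ring, the two groups cannot be told apart, and the methyl of compound 1 is not required for the activity seen with that compound. Nothing available explains why the exchange leaves the number within the scatter.

As far as these compounds go, whether a hydrogen, a fluoro or a methoxy on the same carbon would also stay within the scatter remains open. From the compounds shown here alone, it is equally open whether chloro and methyl would match when the rest of the molecule carries a different group in place of the methylphenyl of compound 1.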